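The source may report more compounds than this note shows. Statements on the series, on what has been measured and on what is new or still open speak of the compounds shown alone.

Measured in an ADME assay on HepG2 cells (Homo sapiens) for cytotoxicity, with a stated time of 72 h; on this read-out lower numbers stand for an effect already at smaller amounts and higher numbers for an effect only at larger amounts of compound:

Compound 1 `Cc1cc(NC(=O)Nc2ccccc2N)c2ccccc2n1`: > 25000 nM (a limit, not a number)
Compound 2 `Cc1cc(NC(=O)Nc2cc(F)cc(F)c2)c2ccccc2n1`: > 25000 nM (a limit, not a number)
Compound 3 `COC(=O)c1cccc(NC(=O)Nc2cc(C)nc3ccccc23)c1`: 23000 nM

Among the measured compounds shown here, of these three results, only the one for compound 3 is an actual number. Compound 3 gives 23000 nM in this assay. The other two results are limits, and the set is marked by the limit of > 25000 nM in this assay, at which 2 of the 3 values shown sit.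

The next compound to be tested is compound 4 `Cc1cc(NC(=O)Nc2cccc(OC(F)(F)F)c2)c2ccccc2n1`. It keeps the core of compound 3 and carries trifluoromethoxy in place of methoxycarbonyl on an aromatic carbon, meta to a large group (trifluoromethoxy in place of methoxycarbonyl on an aromatic carbon).

For the measured compounds named here, no two measured compounds differ in only one place, so the data give no direct measure of what a single change does in this assay. The expectation therefore rests on the narrow picture so far, with compound 3 at 23000 nM. The results for the other two compounds are limits. A step beyond the usual scatter is not expected, in either direction. The expected change is a 1.0-fold higher number from compound 3 to compound 4 (0.02 log units; within the scatter). The assay may well report only a limit for compound 4. As a number, compound 4 is estimated at 24000 nM, with an expected range of 12000 nM to 45000 nM.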

Compound 4, half-maximal effective concentration: 13000 nM
Estimate against measurement, compound 4: 1.8-fold (0.27 log units) above; measured number inside the range.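

Among the compounds shown here, the pair gives the first reading of a single change in this assay: with trifluoromethoxy in place of methoxycarbonyl on an aromatic carbon, meta to a large group, the step is a 1.8-fold lower number from compound 3 to compound 4 (0.25 log units; within the scatter). The two groups differ in their atoms, since one carries a double bond outside aromatic rings and the other carries fluorine, and in their count of hydrogen-bond acceptors, yet at this place the exchange gives no step beyond the usual scatter. Compound 1 and compound 2 still stand at a limit, which is not a number, so the comparison rests on this one pair alone: the limit of > 25000 nM in this assay, at which 2 of the 4 values shown sit.

A single exchange at a single place cannot show whether the same holds at any other place on this ring or for a different group at this one. A carboxylic acid or a longer alkyl chain on this aromatic carbon could stay within the scatter of compound 3 or move clearly away from it, and the compounds shown do not settle which.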